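This account rests on a few compounds, and the source may have more. Where it says the series, first, only, none or still open, it means among the compounds named here.

Three selenium-containing nucleoside analogues have been tested for their ability to kill a human breast cancer cell line. The first, compound 1 `[N-]=[N+]=N[C@@H]1C(n2ccc(=O)[nH]c2=O)[Se][C@H](CO)[C@H]1O`, reaches only the limit of a functional assay on T47D cells (Homo sapiens) for cytotoxicity, read by sulforhodamine B assay (on this read-out higher numbers stand for weaker inhibition and lower numbers for stronger inhibition), giving > 100000 nM. The second, compound 2 `Cc1cn(C2[Se][C@H](CO)[C@@H](O)[C@@H]2O)c(=O)[nH]c1=O`, likewise reaches only the limit of this assay, giving > 100000 nM. Among the compounds with values here, compound 3 `[N-]=[N+]=N[C@@H]1C(n2ccc(N)nc2=O)[Se][C@H](CO)[C@H]1O` is the one member of the set that yields an actual number rather than a limit: in this assay compound 3 gives 78400 nM, which still marks it as a weak inhibitor of cell growth. Compound 3 thus stands at the only measured point, with the two other compounds sitting at the limit, as noted in the limit of > 100000 nM in this assay, at which 2 of the 3 values shown sit.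

Compound 4 `Nc1ccn(C2[Se][C@H](CO)[C@@H](O)[C@@H]2O)c(=O)n1` has not yet been measured. It differs from compound 3 by a single change, (hydroxy in place of azido on a saturated ring carbon); in words, hydroxy in place of azido on a saturated ring carbon. Because compound 2, which also carries a hydroxy group at that position, gave > 100000 nM, the step is expected to run toward weaker inhibition or to sit within the scatter, and a 1.9-fold higher number from compound 3 to compound 4 (0.28 log units; within the scatter) is estimated accordingly. Compound 4 is therefore expected to give about 150000 nM, within a range from 60000 nM to 400000 nM.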

Compound 4, half-maximal inhibitory concentration: 8910 nM
Beside the measured number, compound 4's estimate is 17-fold (1.23 log units) above it; the whole stated range lies above it.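

On the saturated ring carbon two ring bonds from the ring selenium, the group matters for cell killing: in this assay, hydroxy in place of azido gives an 8.8-fold lower number from compound 3 to compound 4 (0.94 log units; beyond the scatter), a step beyond the scatter and toward stronger inhibition. Within the data shown here, none of the earlier compounds formed a pair differing in this one place, so this is the first direct reading of the position, and it shows that the azido group is not required for activity on this core. Compound 1 and compound 2 still give only a limit and no number: the limit of > 100000 nM in this assay, at which 2 of the 4 values shown sit.

The compounds shown cover only azido and hydroxy on this carbon, so they cannot tell how an amine, a fluorine atom or a methoxy group would fare there. They also leave open whether the same change would give a step of similar size on a different core, as this single pair is all that speaks to it.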